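Chloro to Trifluoromethoxy on a Series Showing No Inhibition

A few compounds are considered here, and "the series" means these few. Any claim that something is new, unique, unknown or untested is made for them only; others in the source may bear on it.

Of the compounds shown here, three sharing one core have been tested in an assay on CHO cells for displacement of a labelled ligand from adenosine receptor A3 (Homo sapiens), read by scintillation counting, tested at 10 uM; on this read-out lower numbers stand for less inhibition and higher numbers for more inhibition at the one concentration tested (going by the name of the read-out). Compound 1 `CC(C)(C)Cc1c(-c2ccccn2)sc(N)c1C(=O)c1ccc(Cl)cc1` gives 1%. Compound 2 `CC(C)(C)Cc1c(-c2cc(F)ccc2F)sc(N)c1C(=O)c1ccc(Cl)cc1` gives 1%, and compound 3 `CC(C)(C)Cc1c(-c2ccc(Cl)cc2)sc(N)c1C(=O)c1ccc(Cl)cc1` gives 1%. The three steps among them, no change at the digits printed from compound 1 to compound 2 (within the scatter), no change at the digits printed from compound 1 to compound 3 (within the scatter) and no change at the digits printed from compound 2 to compound 3 (within the scatter), show that exchanging the aryl group on the aromatic carbon left the read-out flat. Compound 3 therefore stands level with compounds 1 and 2, with compound 1 nearest and compound 2 furthest, both differences within the scatter.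

Compound 4 `CC(C)(C)Cc1c(-c2ccc(OC(F)(F)F)cc2)sc(N)c1C(=O)c1ccc(Cl)cc1` differs from compound 3 in one place: trifluoromethoxy in place of chloro on an aromatic carbon. Within the data shown here, no measured step touches this part of the molecule, so none bears on it directly; the only guidance is that every step seen so far, all on a different ring, stayed within the scatter, and that no compound has moved off the floor. The expected step is no change at the digits printed from compound 3 to compound 4 (within the scatter), meaning no change beyond the scatter. Compound 4 is thus estimated at 1%, with a range from -8% to 12%, because compound 3 gives 1%.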

Compound 4, a percentage reported as inhibition, at one concentration (the size of the read-out at that concentration, not a potency): 1%
Estimate against measurement, compound 4: no gap at the digits printed, and the stated range covers the measured number.
By their numbers in this assay, from the lowest: compounds 1, 2, 3 and 4 (each within the scatter of the next).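

In this assay, replacing chloro with trifluoromethoxy, which brings more heavy atoms and a hydrogen-bond acceptor that chloro lacks, gives no change at the digits printed from compound 3 to compound 4 (within the scatter) and thus no detectable effect. The earlier steps shown here exchanged the whole aryl group, whereas this one keeps the ring and changes only the group on it, para to a large group, and this also leaves the read-out flat. With every compound close to no inhibition, this flat result cannot show whether the position matters for binding, and nothing available explains the result.

Going by these compounds, whether an amine or a carboxylic acid at this position would raise the inhibition remains open. The same question stands for a longer chain there, and for any replacement of the chloro on the other ring.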